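The source may report more compounds than this note shows. Statements on the series, on what has been measured and on what is new or still open speak of the compounds shown alone.

Measured in a physicochemical assay for solubility, read by HPLC; on this read-out higher numbers stand for higher solubility and lower numbers for lower solubility:
- compound 1 `C=CCc1ccc(O)c(-c2cc(CC=C)cc([C@@H]3C=C(C)CC[C@H]3C(C)C)c2O)c1`: < 10 ug/mL (a limit)
- compound 2 `C=CCc1ccc(O)c(-c2cc(CC=C)cc(CN3CCC(N)CC3)c2O)c1`: > 1000000 ug/mL (a limit)

In this assay compound 2 gives > 1000000 ug/mL, which is a limit of the assay and not a number. Compound 3 `C=CCc1ccc(O)c(-c2cc(CC=C)cc(CN3CCCC(N)C3)c2O)c1` has not yet been measured. It has the same atoms as compound 2, joined differently: 3-aminopiperidin-1-yl in place of 4-aminopiperidin-1-yl on a saturated chain carbon bound to an aromatic carbon. Within the data shown here, no measured step covers this exchange. Among the measured compounds shown here, the only measured step, an at least 100000-fold higher number from compound 1 to compound 2 (5.00 log units; beyond the scatter), is large and beyond the scatter, but it puts (4-aminopiperidin-1-yl)methyl in place of 6-isopropyl-3-methylcyclohex-2-en-1-yl and joins two limits, so it sets no size for a move that keeps the atoms unchanged. No change beyond the scatter is therefore expected, and the estimated step is a number no higher from compound 2 to compound 3 (the limit leaves the size open). The value estimated for compound 3 is 1000000 ug/mL, with an expected range of 300000 ug/mL to 3000000 ug/mL.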

Compound 3, solubility: 4080 ug/mL
Compound 3: middle estimate off by 250-fold (2.39 log units), on the high side; the whole stated range lies above it.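

In this assay, putting 3-aminopiperidin-1-yl in place of 4-aminopiperidin-1-yl on a saturated chain carbon bound to an aromatic carbon keeps the same atoms yet gives an at least 240-fold lower number from compound 2 to compound 3 (2.38 log units; beyond the scatter), so at this place the way those atoms are joined matters, not only which atoms are present. Even with this exchange, the other comparison remains large: an at least 400-fold higher number from compound 1 to compound 3 (2.61 log units; beyond the scatter). Compound 1 and compound 2 each stand at a limit of the assay, not at a number, and both steps give only a smallest size.

The compounds shown do not tell why the two joinings differ. Going by these compounds, it also remains open whether a piperazine ring or a 3-aminopyrrolidin-1-yl group at this place would read closer to compound 2 or to compound 3 in this assay.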